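Swapping the benzyl aryl group in a sulfonamide diamine series

The source may hold more compounds than are shown below. What is called first, only, known or untested is meant among the compounds shown, and "the series" means these compounds.

Compound 1 `O=S(=O)(NCCCNCc1ccccc1Cl)c1cc(C(F)(F)F)cc(C(F)(F)F)c1`: 15000 nM
Compound 2 `COc1ccc(CNCCCNS(=O)(=O)c2cc(C(F)(F)F)cc(C(F)(F)F)c2)cc1OC`: 18000 nM

Compound 1 and compound 2 share the same bis(trifluoromethyl)phenylsulfonamide core and differ only in the aryl group carried by the benzylic amine. In a functional assay on PANC-1 cells (Homo sapiens) for inhibition, read by MTT assay, with a stated time of 72 h (on this read-out higher numbers stand for weaker inhibition of growth and lower numbers for stronger inhibition of growth), compound 1 gives 15000 nM and compound 2 gives 18000 nM. Compound 2 holds the higher of the two numbers, but the step of a 1.2-fold higher number from compound 1 to compound 2 (0.08 log units; within the scatter) is within the scatter, so the two compounds are not distinguished by this assay.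

Compound 3 `O=S(=O)(NCCCNCc1ccc(C(F)(F)F)cc1)c1cc(C(F)(F)F)cc(C(F)(F)F)c1` carries the change (4-(trifluoromethyl)phenyl in place of 3,4-dimethoxyphenyl on a saturated chain carbon bound to an amine nitrogen). Among the compounds with values here, the only measured step that bears on it is the aryl exchange from compound 1 to compound 2, which was within the scatter. A step of comparable size, with no clear direction, is therefore expected from compound 2 to compound 3, a 1.2-fold lower number from compound 2 to compound 3 (0.08 log units; within the scatter). Compound 3 is accordingly estimated to give 15000 nM in this assay, with a range from 6000 nM to 40000 nM.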

Compound 3, concentration for 50% growth inhibition: 3200 nM
Compound 3: the middle estimate sits 4.7-fold (0.67 log units) above what was measured; measured number below the stated range.
By their numbers in this assay, from the lowest: compound 3; then compounds 1 and 2 (each within the scatter of the next).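

Placing 4-(trifluoromethyl)phenyl on this saturated chain carbon bound to an amine nitrogen gives a 5.6-fold lower number from compound 2 to compound 3 (0.75 log units; beyond the scatter) and a 4.7-fold lower number from compound 1 to compound 3 (0.67 log units; beyond the scatter) in this assay and so shows that the aryl group here can shift growth inhibition, which the exchange of 2-chlorophenyl and 3,4-dimethoxyphenyl did not show. Among the three compounds, compound 3 alone stands apart, though both steps are modest in size. Nothing measured here accounts for this difference.

From the compounds shown here alone, it remains open whether the trifluoromethyl group itself or its place on the ring sets compound 3 apart, and whether a 4-chlorophenyl or 4-methoxyphenyl group would match compound 3 or fall with compounds 1 and 2. Going by these compounds, how a longer chain in the linker would act on this step also remains open.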